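The source may report more compounds than this note shows. Statements on the series, on what has been measured and on what is new or still open speak of the compounds shown alone.

Compound 1 `Cc1ccccc1Nc1ncnn1-c1cccc(Cl)c1Cl` is the reference point of this small set. In a functional assay for antagonist activity at P2X purinoceptor 7 (Homo sapiens), read by FLIPR and calcium flux (a lower number here means a stronger inhibitor, a higher number a weaker inhibitor), compound 1 gives 17.8 nM. Compound 2 `CCc1ccccc1Nc1ncnn1-c1cccc(Cl)c1Cl` differs from it by one change, (methyl in place of hydrogen on a saturated chain carbon bound to an aromatic carbon), and in this assay compound 2 gives 45.7 nM. The step of a 2.6-fold higher number from compound 1 to compound 2 (0.41 log units; beyond the scatter) is therefore a real loss of potency, though a modest one.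

Compound 3 `COc1ccccc1CNc1ncnn1-c1cccc(Cl)c1Cl` carries a different core; the difference between its core and the core of compound 1 is not broken down here. In this assay compound 3 gives 57.5 nM. Its number and that of compound 2 lie within the usual scatter of each other, so nothing separates the two; against compound 1 the number of compound 3 is higher, and that gap is beyond the scatter.

Compound 4 `CCOc1ccccc1CNc1ncnn1-c1cccc(Cl)c1Cl` has not yet been measured. Relative to compound 3 it carries the change (methyl in place of hydrogen on a saturated chain carbon bound to an oxygen on an aromatic ring). This is the same kind of change as that from compound 1 to compound 2, but not the same: there the methyl entered on a saturated chain carbon bound to an aromatic carbon, here it enters on a saturated chain carbon bound to an oxygen on an aromatic ring. Resting on the step of a 2.6-fold higher number from compound 1 to compound 2 (0.41 log units; beyond the scatter) seen for compound 1 and compound 2, compound 4 is expected to show a step of about a 1.9-fold higher number from compound 3 to compound 4 (0.28 log units; within the scatter) in this assay. Compound 4 is accordingly estimated at 110 nM, with a plausible range from 40 nM to 300 nM.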

Compound 4, half-maximal inhibitory concentration: 45.7 nM
Compound 4: middle estimate off by 2.4-fold (0.38 log units), on the high side; the measured number falls inside the stated range.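

In this assay the new step is a 1.3-fold lower number from compound 3 to compound 4 (0.10 log units; within the scatter), so the change from methoxy to ethoxy leaves nothing that separates compound 3 from compound 4. The loss of potency seen when methyl to ethyl turned compound 1 into compound 2 therefore did not carry over to this second pair, and the two steps differ by more than their scatter allows: the same change on two cores in this assay, a 2.6-fold higher number (0.41 log units; beyond the scatter) from compound 1 to compound 2 and a 1.3-fold lower number (0.10 log units; within the scatter) from compound 3 to compound 4, 3.2-fold (0.51 log units) apart, beyond the scatter of two such steps. Among these compounds, this shows that, within this series, the step measured on one core cannot simply be transferred to the other, but it does not show why, since the two pairs differ both in their core and in the place of the change, and with only one pair on each core the two differences cannot be pulled apart.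

The compounds shown leave open whether the methoxy and ethoxy groups would give the same result on the core of compound 1, and whether methyl to ethyl would behave on the core of compound 3 as it did on the core of compound 1. They also leave open how a longer chain such as propyl, or an amine or a carboxylic acid at the end of that chain, would read in this assay.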